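This account rests on a few compounds, and the source may have more. Where it says the series, first, only, none or still open, it means among the compounds named here.

Measured so far in a physicochemical assay for solubility, in phosphate buffer, with a stated time of 18 h (a higher number here means a more soluble compound, a lower number a less soluble compound), are two compounds:
compound 1 `CC(C)(C)c1nc(-c2cccs2)c2c(N)c(C#N)c(N)nc2n1` at 56000 nM
compound 2 `CC(C)(C)c1nc(-c2cnccn2)c2c(N)c(C#N)c(N)nc2n1` at 86000 nM

On these numbers compound 2 does not separate from compound 1. For the measured compounds named here, the one available step is a 1.5-fold higher number from compound 1 to compound 2 (0.19 log units; within the scatter) and it places pyrazin-2-yl in place of thiophen-2-yl on an aromatic carbon.

The next structure is compound 3 `CC(C)(C)c1nc(-c2ccc(C(=O)O)s2)c2c(N)c(C#N)c(N)nc2n1` with 5-carboxythiophen-2-yl in place of pyrazin-2-yl on an aromatic carbon, and the full count of the change reads 5-carboxythiophen-2-yl in place of pyrazin-2-yl on an aromatic carbon in detail. Going by the values given here, the step between the two measured compounds is the only one bearing on this change. Among the compounds with values here, it covers the exchange of the two rings, but no measured step covers a carboxy-bearing group, so the data give no direct guide to its size.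

In this assay a modest step to a higher number, just beyond the scatter, is nonetheless expected, as a judgement from the structural change alone. The expected change is a 2.3-fold higher number from compound 2 to compound 3 (0.37 log units; beyond the scatter) as an estimate with a wide margin. The estimated value for compound 3 is 200000 nM within an expected range of 70000 nM to 500000 nM for now.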

Compound 3, solubility: > 1000000 nM
Compound 3 gave a limit, no number; the forecaster's own chance of this, stated with the estimate: 30%; middle value at least 5.0-fold (0.69 log units) away from the limit.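

In this assay, the exchange of one ring for the other at this position did not separate the first two compounds, but a single added group on the attached ring does move the read-out. Carboxy in place of hydrogen on an aromatic carbon, the only change on the thiophen-2-yl compound, gives an at least 17-fold higher number from compound 1 to compound 3 (1.25 log units; beyond the scatter), and 5-carboxythiophen-2-yl in place of pyrazin-2-yl gives an at least 11-fold higher number from compound 2 to compound 3 (1.06 log units; beyond the scatter), so among these three compounds the substituent on the attached ring counts for far more than the choice of ring. Compound 3 gives a limit of the assay and not a number, which leaves the full size of both steps unfixed: the limit of > 1000000 nM in this assay, at which 1 of the 3 values shown sits.

Still open, from the compounds shown here alone, is whether the carboxy group would give a step of similar size on the pyrazin-2-yl ring, or whether the large step belongs to the 5-carboxythiophen-2-yl group as a whole. Also open, going by these compounds, is whether a methyl ester, a primary amide or an amine on the same ring would give a step of this size, or whether the carboxylic acid alone does so.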